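Cytotoxicity series: nitrophenyl replaces benzodioxinyl on the biaryl

A few compounds are considered here, and "the series" means these few. Any claim that something is new, unique, unknown or untested is made for them only; others in the source may bear on it.

Two compounds of the series have been run in an ADME assay on BJ cells (Homo sapiens) for cytotoxicity, read by CellTiter-Glo and resazurin assay, with a stated time of 72 h; on this read-out lower numbers stand for an effect already at smaller amounts and higher numbers for an effect only at larger amounts of compound. In this assay compound 1 `CC(C)N(Cc1cccc(OCCCCCC(=O)O)c1)C(=O)c1ccc(-c2cccc(N(C)C)c2)cc1` gives > 26000 nM, which is a limit of the assay and not a number. Compound 2 `CC(C)N(Cc1cccc(OCCCCCC(=O)O)c1)C(=O)c1ccc(-c2ccc3c(c2)OCCO3)cc1` gives > 21900 nM, again a limit of the assay rather than a measured number. Within the data shown here, the one step between measured compounds, a step that the two limits leave unreadable from compound 1 to compound 2, cannot be read in size because the limit of > 26000 nM in this assay, at which 1 of the 2 values shown sits, and the limit of > 21900 nM in this assay, at which 1 of the 2 values shown sits, mark both of its ends. Among the measured compounds shown here, compound 2 therefore stands at a limit, and the one further value shown is also a limit, so no ordering among the two can be made.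

Compound 3 `CC(C)N(Cc1cccc(OCCCCCC(=O)O)c1)C(=O)c1ccc(-c2cccc([N+](=O)[O-])c2)cc1` differs from compound 2 by 3-nitrophenyl in place of 2,3-dihydro-1,4-benzodioxin-6-yl on an aromatic carbon. For the measured compounds named here, no measured step bears readably on this change, since the single step available stays unreadable. The expectation for compound 3 is therefore a step that the limit leaves unreadable from compound 2 to compound 3, that is, no change beyond the scatter and most likely another limit. The estimated value for compound 3 is 25000 nM, within 10000 nM to 60000 nM.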

Compound 3, half-maximal effective concentration: > 26000 nM
Compound 3 gave a limit, no number (the forecaster's own chance of this, stated with the estimate: 80%); at least 1.0-fold (0.01 log units) between middle value and limit.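

Compound 1, compound 2 and compound 3 all stand at limits of the assay and not at numbers, so none of the steps among them can be read. The compounds shown leave open at what concentration any of the three would show an effect, and whether 3-nitrophenyl, 2,3-dihydro-1,4-benzodioxin-6-yl and 3-(dimethylamino)phenyl differ at all.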